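The source may hold more compounds than are shown below. What is called first, only, known or untested is meant among the compounds shown, and "the series" means these compounds.

Measured so far in a functional assay on MCF7 cells (Homo sapiens) for cytotoxicity, read by MTT assay, with a stated time of 48 h, tested at 20 uM; a lower number here means less inhibition, a higher number more inhibition at the concentration tested (going by the name of the read-out):
compound 1, `CO[C@H]1O[C@H](COc2ccc3c(c2)CCCC3)[C@@H](O)[C@H](O)[C@H]1Oc1ccc(OC2CCCCC2)cc1`: 45%
compound 2, `CO[C@@H]1O[C@H](COc2ccc3c(c2)CCCC3)[C@@H](O)[C@H](O)[C@H]1Oc1ccc(OC2CCCCC2)cc1`: 14%

Going by the values given here, compound 2 stands lowest of the two numbers; its nearest neighbour is compound 1, and the only measured step is a number 31 percentage points lower from compound 1 to compound 2 (beyond the scatter), which rests on the fact that compounds 1 and 2 differ only in the configuration as drawn alone, the two compounds having the same atoms and bonds.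

Compound 3, `CO[C@@H]1O[C@H](COc2ccc(-c3ccccc3)cc2)[C@@H](O)[C@H](O)[C@H]1Oc1ccc(OC2CCCCC2)cc1`, keeps the configuration of compound 2 and differs from it in one place: 4-phenylphenyl in place of 1,2,3,4-tetrahydronaphthalen-6-yl on an oxygen on a saturated carbon. Among the compounds with values here, no measured step exchanges the aryl group on that oxygen, and the step from compound 1 to compound 2, a configurational one, does not bear on an aryl swap. The size and direction of the coming step are therefore open; the expected step is a number 6 percentage points higher from compound 2 to compound 3 (within the scatter), set near compound 2 with a wide band. For compound 3 the estimate in this assay is 20%, between 5% and 45%.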

Compound 3, a percentage reported as inhibition, at one concentration (the size of the read-out at that concentration, not a potency): 51%
Estimate against measurement, compound 3: 31 percentage points below, outside the stated range (above it).
By their numbers in this assay, from the lowest: compound 2; then compounds 1 and 3 (each within the scatter of the next).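

In this assay the aryl group on the oxygen on a saturated carbon emerges as a second place that moves the read-out, with a number 37 percentage points higher from compound 2 to compound 3 (beyond the scatter) at unchanged configuration, whereas the earlier pair showed only a configurational change. The low reading of compound 2 is therefore not set by its configuration alone: compound 3 shares that configuration and gives 51% in this series. Nothing shown gives a reason for this aryl exchange.

Open, going by these compounds, is whether the configurational step seen between compound 1 and compound 2 recurs with 4-phenylphenyl in place. Also open, on these data alone, is how the read-out responds at this place to a plain phenyl group, or to a 4-phenylphenyl group carrying an amine or a carboxylic acid.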